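A few compounds are considered here, and "the series" means these few. Any claim that something is new, unique, unknown or untested is made for them only; others in the source may bear on it.

In an ADME assay on MDBK cells (Bos taurus) for cytotoxicity, read by MTT assay, with a stated time of 96 h (a higher number here means that more compound is tolerated, a lower number that less compound is tolerated), compound 1 `C/C(=N\NC(N)=O)c1ccc2c(c1)nc(-c1ccccc1)n2C1CCCCC1` gives > 100000 nM, which is a limit of the assay and not a number. Compound 2 `C/C(=N\NC(N)=O)c1ccc2c(c1)nc(-c1ccc(C(F)(F)F)cc1)n2C1CCCCC1` gives > 100000 nM, again only a limit. Within the data shown here, the single measured step, a step that the two limits leave unreadable from compound 1 to compound 2, therefore has no readable size, and the evidence amounts to the limit of > 100000 nM in this assay, at which 2 of the 2 values shown sit. Compound 3 `COc1ccc(-c2nc3cc(/C(C)=N/NC(N)=O)ccc3n2C2CCCCC2)cc1` differs from compound 2 by one change: methoxy in place of trifluoromethyl on an aromatic carbon, para to a large group. Among the measured compounds shown here, no measured step gives a size or a direction for this change. Because of the limit of > 100000 nM in this assay, at which 2 of the 2 values shown sit, a step beyond the scatter in this assay is not expected. The expected step, a number no higher from compound 2 to compound 3 (the limit leaves the size open), is accordingly small. For compound 3 the estimated value is 100000 nM, with an expected range from 40000 nM to 100000 nM, and the assay may well report only a limit again.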

Compound 3, half-maximal cytotoxic concentration: 54000 nM
Compound 3: the middle estimate sits 1.9-fold (0.27 log units) above what was measured; the range from low to high includes it.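

In this assay compound 3 is the only one of the three compounds shown that gives a number and not a limit, so the aromatic carbon para to a large group is a place where a change can be read in this assay. Methoxy in place of trifluoromethyl gives an at least 1.8-fold lower number from compound 2 to compound 3 (0.26 log units; that floor lies within the scatter), and methoxy in place of hydrogen gives an at least 1.8-fold lower number from compound 1 to compound 3 (0.26 log units; that floor lies within the scatter). As far as these compounds go, compound 1 and compound 2 each stand at a limit, so both steps have only a floor, the true sizes stay open, and the step between compound 1 and compound 2 cannot be read.

The compounds shown leave open whether a hydroxyl, an ethoxy or an amine on the same carbon would give a lower number than methoxy or return to the limit. Also open, from the compounds shown here alone, is whether methoxy would give a similar step on another carbon of that aromatic ring.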